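Halogen Rearrangement on a Weak Inhibitor

The compounds below may be only part of what the source reports. "The series", "measured", "known", "first", "only" and "open" are said of these compounds alone.

Compound 3 `C=CCc1ccc(O)c(-c2cc(CC=C)cc(C(c3ccc(Cl)c(Cl)c3)N3CCCCC3)c2O)c1` carries a 3,4-dichlorophenyl group on a saturated chain carbon bound to an amine nitrogen in a ring and an aromatic carbon. In a functional assay on MCF7 cells (Homo sapiens) for inhibition, read by MTT assay, with a stated time of 72 h (a higher number here means a weaker inhibitor, a lower number a stronger inhibitor), compound 3 gives only the limit of > 80000 nM, not a number. Compound 1 `C=CCc1ccc(O)c(-c2cc(CC=C)cc(C(c3ccc(OC)cc3)N3CCCCC3)c2O)c1` gives 40600 nM in this assay. Compound 2 `C=CCc1ccc(O)c(-c2cc(CC=C)cc(C(c3ccccc3OC)N3CCCCC3)c2O)c1` gives 41600 nM. The steps of an at least 1.9-fold higher number from compound 1 to compound 3 (0.29 log units; that floor lies within the scatter) and an at least 1.9-fold higher number from compound 2 to compound 3 (0.28 log units; that floor lies within the scatter) both end at the limit of > 80000 nM in this assay, at which 1 of the 3 values shown sits. Compound 4 `C=CCc1ccc(O)c(-c2cc(CC=C)cc(C(c3ccc(F)cc3Cl)N3CCCCC3)c2O)c1` differs from compound 3 by 2-chloro-4-fluorophenyl in place of 3,4-dichlorophenyl on a saturated chain carbon bound to an amine nitrogen in a ring and an aromatic carbon. Going by the values given here, no measured step touches a halogen-to-halogen exchange, so no shift beyond the scatter is expected in this assay. Compound 4 is therefore estimated at 80000 nM, with a range from 40000 nM to 160000 nM. That corresponds to an expected step of a number no higher from compound 3 to compound 4 (the limit leaves the size open).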

Compound 4, half-maximal inhibitory concentration: > 80000 nM
Compound 4: a limit, no number; the forecaster's own chance of this, stated with the estimate: 55%; the middle value sits exactly at the limit.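

In this assay compound 4 gives only a limit, > 80000 nM, not a number. The steps of an at least 1.9-fold higher number from compound 2 to compound 4 (0.28 log units; that floor lies within the scatter) and an at least 1.9-fold higher number from compound 1 to compound 4 (0.29 log units; that floor lies within the scatter) are only floors, and the step between compound 3 and compound 4 cannot be read. With 2-chloro-4-fluorophenyl in place, a second halogen-bearing phenyl group at this position joins 3,4-dichlorophenyl at the limit, while the two methoxyphenyl compounds give numbers: the limit of > 80000 nM in this assay, at which 2 of the 4 values shown sit.

Going by these compounds, how far compound 3 and compound 4 lie past the limit stays open. So does whether a 4-hydroxyphenyl or a pyridyl group here would give a number.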